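Adding a trifluoromethyl group to compound 3

The source may report more compounds than this note shows. Statements on the series, on what has been measured and on what is new or still open speak of the compounds shown alone.

In a functional assay on V79 cells (Cricetulus griseus) for cytotoxicity, read by colony formation (on this read-out lower numbers stand for stronger inhibition and higher numbers for weaker inhibition), compound 1 `O=C(O)c1cn(C2CC2)c2c(C(F)(F)F)c(N3CCCC3)c(F)cc2c1=O` gives 280 ug/mL and compound 2 `NCC1CCN(c2c(F)cc3c(=O)c(C(=O)O)cn(C4CC4)c3c2C(F)(F)F)C1` gives 38 ug/mL. Compound 3 `CC1(CN)CCN(c2cc3c(cc2F)c(=O)c(C(=O)O)cn3C2CC2)C1` gives 23 ug/mL, which lies within the scatter of compound 2 and clearly under compound 1. Compound 4 `CC1(CN)CCN(c2c(F)cc3c(=O)c(C(=O)O)cn(C4CC4)c3c2C(F)(F)F)C1` is compound 3 with trifluoromethyl in place of hydrogen on an aromatic carbon. Among the compounds with values here, the one measured step, a 7.4-fold lower number from compound 1 to compound 2 (0.87 log units; beyond the scatter), came from aminomethyl in place of hydrogen on a saturated ring carbon. Within the data shown here, that is a different change, so it bears only indirectly, and no measured step isolates the trifluoromethyl. The nearest evidence is compound 2, which already carries trifluoromethyl and differs from compound 4 only by lacking the methyl of the 3-(aminomethyl)-3-methylpyrrolidin-1-yl group. Because compound 2 gives 38 ug/mL with trifluoromethyl in place, no move beyond the scatter is expected. The expected step is a 1.3-fold higher number from compound 3 to compound 4 (0.12 log units; within the scatter). The estimate for compound 4 is 30 ug/mL, with an expected range of 10 ug/mL to 90 ug/mL.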

Compound 4, half-maximal inhibitory concentration: 110 ug/mL
Estimate against measurement, compound 4: 3.7-fold (0.56 log units) below; measured number above the stated range.
By their numbers in this assay, from the lowest: compounds 3 and 2 (each within the scatter of the next); then compound 4; then compound 1.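

In this assay, within the data shown here, trifluoromethyl in place of hydrogen on the aromatic carbon ortho to the 3-(aminomethyl)-3-methylpyrrolidin-1-yl group gives the first direct reading of this change, and it weakens inhibition beyond the scatter (a 4.8-fold higher number from compound 3 to compound 4 (0.68 log units; beyond the scatter)). With trifluoromethyl present, the extra methyl of the 3-(aminomethyl)-3-methylpyrrolidin-1-yl group also weakens inhibition (a 2.9-fold higher number from compound 2 to compound 4 (0.46 log units; beyond the scatter)), so the two changes cannot be judged from compound 2 alone. The 3-(aminomethyl)-3-methylpyrrolidin-1-yl group still gives stronger inhibition than pyrrolidin-1-yl on the same trifluoromethyl-bearing core (a 2.5-fold lower number from compound 1 to compound 4 (0.41 log units; beyond the scatter)).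

Nothing measured here explains why either step goes the way it does. From the compounds shown here alone, whether a smaller group on that aromatic carbon, such as chloro or methoxy, would raise the number as trifluoromethyl does remains open, as does the size of this step with other amine side chains.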